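Sulfur-side group swap in the shared core series

This account rests on a few compounds, and the source may have more. Where it says the series, first, only, none or still open, it means among the compounds named here.

Three analogues of the shared core carry a measurement in a functional assay on MGC-803 cells (Homo sapiens) for inhibition, read by MTT assay, with a stated time of 72 h; on this read-out higher numbers stand for weaker inhibition and lower numbers for stronger inhibition. Compound 1 `Cc1cc(Nc2ccn(Cc3cccc4ccccc34)n2)n2nc(SCc3ccc(Br)cc3)nc2n1` gives 3240 nM. Compound 2 `Cc1cc(Nc2cc(-c3ccccc3)[nH]n2)n2nc(SCc3nc4ccccc4[nH]3)nc2n1` gives 1790 nM, the lowest of the three numbers, although its gap to compound 1 lies within the scatter, so no order between those two is claimed. Compound 3 `Cc1ccc(Cn2ccc(Nc3cc(C)nc4nc(SCc5ccc(Br)cc5)nn34)n2)cc1` gives 7420 nM. Within the data shown here, the only single-place step among the measured compounds is a 2.3-fold higher number from compound 1 to compound 3 (0.36 log units; beyond the scatter), a change on a saturated chain carbon bound to an aromatic nitrogen. Compound 4 `Cc1cc(Nc2cc(-c3ccccc3)[nH]n2)n2nc(SCC(=O)c3ccccc3)nc2n1` differs from compound 2 by benzoyl in place of 1H-benzimidazol-2-yl on a saturated chain carbon bound to a sulfur. Among the measured compounds shown here, no measured pair alters the group on the saturated chain carbon bound to a sulfur, so the step from compound 1 to compound 3 does not bear on this change, and compounds 1 and 2 differ in two places and supply no isolated step either. For the measured compounds named here, with no direct precedent, no change beyond the scatter is expected in this assay. The estimate for compound 4 is 2500 nM, with a range of 900 nM to 7000 nM. The expected step is a 1.4-fold higher number from compound 2 to compound 4 (0.15 log units; within the scatter).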

Compound 4, half-maximal inhibitory concentration: 2580 nM
The estimate for compound 4 lay 1.0-fold (0.01 log units) below the measured number; low and high end bracket the measured number.
By their numbers in this assay, from the lowest: compounds 2, 4 and 1 (each within the scatter of the next); then compound 3.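

Among these compounds, the step of a 1.4-fold higher number from compound 2 to compound 4 (0.16 log units; within the scatter) in this assay is the only isolated reading at the saturated chain carbon bound to a sulfur. Benzoyl and 1H-benzimidazol-2-yl therefore cannot be told apart here, although the change removes the five-membered aromatic ring and the hydrogen-bond donor and brings in a carbonyl. No supporting measurement explains this outcome.

As far as these compounds go, with only these two groups compared on this carbon, it remains open whether a group without an aromatic ring, such as a carboxylic acid, a primary amine or a longer alkyl chain, would give a similar number. From the compounds shown here alone, it also remains open whether the same swap would give a similar step with the naphthalen-1-yl group of compound 1 in place of the phenyl-bearing side of compound 2.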